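The source may hold more compounds than are shown below. What is called first, only, known or untested is meant among the compounds shown, and "the series" means these compounds.

In a functional assay (Mus musculus) for inhibition, read by cell counting, with a stated time of 3 days (on this read-out higher numbers stand for weaker inhibition and lower numbers for stronger inhibition), compound 1 `COc1ccc(N(C)c2nc(C)nc3c2nc(C)n3C)cc1` gives 8700 nM. Compound 2 `Cc1ccc(N(C)c2nc(C)nc3c2nc(C)n3C)cc1` is known only by a limit, > 100000 nM, so it has no number of its own and stands at the weak end of the assay's range.

Compound 3 `Cc1nc(N(C)c2ccc(OC(F)(F)F)cc2)c2nc(C)n(C)c2n1` differs from compound 2 as follows: trifluoromethoxy in place of methyl on an aromatic carbon. This puts trifluoromethoxy in place of methyl on an aromatic carbon, para to a large group.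

Within the data shown here, one measured step bears on this change. Methyl in place of methoxy at that same place gave an at least 11-fold higher number from compound 1 to compound 2 (1.06 log units; beyond the scatter), which is a large loss. Trifluoromethoxy also joins the ring through oxygen, but it is not methoxy, so only part of that loss is expected to be regained, with compound 1 at 8700 nM as the guide.

The expected change is an at least 3.3-fold lower number from compound 2 to compound 3 (0.52 log units; beyond the scatter), towards stronger inhibition in this assay. For compound 3 the estimated value is 30000 nM, with an expected range of 6000 nM to 100000 nM.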

Compound 3, half-maximal inhibitory concentration: > 100000 nM
Compound 3 was reported as a limit; the forecaster's own chance of this, stated with the estimate: 30%; at least 3.3-fold (0.52 log units) between middle value and limit.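

The oxygen joining the group to the ring is not enough on its own at this position: with trifluoromethyl in place of methyl on that oxygen, the change gives an at least 11-fold higher number from compound 1 to compound 3 (1.06 log units; beyond the scatter). Of the three groups tried on this aromatic carbon, para to a large group, only the methoxy of compound 1 gives a measurable number in this assay, so activity in this small set depends on methoxy itself rather than on any oxygen-linked group. The step from compound 2 to compound 3 cannot be read, because both values are limits: the limit of > 100000 nM in this assay, at which 2 of the 3 values shown sit.

Going by these compounds, how weak compound 2 and compound 3 actually are remains open. Also open, on these data alone, is whether an ethoxy group or an amine at this place would match or improve on compound 1.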